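The source may hold more compounds than are shown below. What is called first, only, known or untested is meant among the compounds shown, and "the series" means these compounds.

Series notes. Compound 1 `CCCCCCCCCCCCNC(=O)[C@@H](NC(=O)/C=C/c1ccccc1)[C@@H](C)O` carries a (2-phenylethenyl)carbonyl group on the amine nitrogen. In a functional assay on MCF7 cells (Homo sapiens) for cytotoxicity, read by MTT assay, with a stated time of 48 h (a higher number here means a weaker inhibitor, a lower number a stronger inhibitor), compound 1 gives only a limit, > 200000 nM, the assay ceiling (the limit of > 200000 nM in this assay, at which 1 of the 2 values shown sits). Among the measured compounds shown here, compound 2 `CCCCCCCCCCCCNC(=O)[C@@H](NS(=O)(=O)c1cccs1)[C@@H](C)O` carries a (thiophen-2-yl)sulfonyl there instead, and in this assay compound 2 gives 19100 nM, the only finite number in the set. The step of an at least 10-fold lower number from compound 1 to compound 2 (1.01 log units; beyond the scatter) is large and concerns the amine substituent alone. Compound 3 `CCCCCCCCCCCCCCNC(=O)[C@@H](NS(=O)(=O)c1cccs1)[C@@H](C)O` differs from compound 2 at the other end: ethyl in place of hydrogen on a saturated chain carbon, ten or more bonds along the chain from an amide-type nitrogen. For the measured compounds named here, no measured step in the set touches the saturated chain, so the amine-substituent step offers no guide to this change, and nothing in the data points to a direction beyond the scatter. Compound 3 is therefore expected to sit close to compound 2. The estimated step of a 1.3-fold lower number from compound 2 to compound 3 (0.10 log units; within the scatter) is expected to lie within the scatter. The estimate for compound 3 in this assay is 15000 nM, with a range from 5000 nM to 50000 nM.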

Compound 3, half-maximal inhibitory concentration: 18700 nM
Estimate against measurement, compound 3: 1.2-fold (0.10 log units) below, within the range that was stated.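

In this assay, the saturated chain now has a measured step of its own: ethyl in place of hydrogen on a saturated chain carbon gives a 1.0-fold lower number from compound 2 to compound 3 (0.01 log units; within the scatter). Among the compounds shown here, with the (thiophen-2-yl)sulfonyl group in place, this chain extension leaves compound 2 and compound 3 indistinguishable, so the only step beyond the scatter in the set remains the one at the amine substituent, an at least 10-fold lower number from compound 1 to compound 2 (1.01 log units; beyond the scatter). No available evidence bears on why the chain step is so small.

As far as these compounds go, it remains open whether a much shorter chain, a longer chain, or a chain ending in an amine or a carboxylic acid would stay as close to compound 2. Also open, from the compounds shown here alone, is whether the same extension would read alike with a (2-phenylethenyl)carbonyl group on the amine nitrogen.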